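Truncating the ketone side chain in the bis-ether series

A few compounds are considered here, and "the series" means these few. Any claim that something is new, unique, unknown or untested is made for them only; others in the source may bear on it.

Three measured compounds share one core and differ only in the carboxyphenyl ring at one end. In an assay on HEK293 cells for positive allosteric modulation of metabotropic glutamate receptor 2 (Rattus norvegicus), read by thallium flux, with a stated time of 2.5 min (on this read-out lower numbers stand for smaller maximal responses and higher numbers for larger maximal responses), compound 1 `Cc1cc(C(=O)O)ccc1OCCCCOc1ccc(C(=O)CC(C)C)c(O)c1C` gives 83.9% and stands second highest of the three. Compound 2 `Cc1ccc(C(=O)O)cc1OCCCCOc1ccc(C(=O)CC(C)C)c(O)c1C` gives 76.9%, and the step of a number 7 percentage points lower from compound 1 to compound 2 (within the scatter) lies within the scatter. Among the compounds with values here, compound 3 `Cc1cc(OCCCCOc2ccc(C(=O)CC(C)C)c(O)c2C)ccc1C(=O)O` gives 93.3%, and the step of a number 9.4 percentage points higher from compound 1 to compound 3 (within the scatter) also lies within the scatter; only the step of a number 16.4 percentage points higher from compound 2 to compound 3 (beyond the scatter) reaches beyond it.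

Compound 4 `CC(=O)c1ccc(OCCCCOc2ccc(C(=O)O)cc2C)c(C)c1O` is unmeasured. It differs from compound 1 at the other end of the molecule: hydrogen in place of isopropyl on a saturated chain carbon bound to a carbonyl carbon. Within the data shown here, none of the measured steps touches this part of the structure; all three alter the carboxyphenyl ring, so no step here bears directly on the change. Among the measured compounds shown here, with no precedent, no step beyond the scatter is expected in this assay, and compound 4 is estimated at 78%, range 58% to 96%, meaning an expected step of a number 5.9 percentage points lower from compound 1 to compound 4 (within the scatter) that stays within the scatter.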

Compound 4, largest response reached (reported as percent of maximum), in percent of the reference or control that the assay uses: 83.1%
For compound 4 the middle estimate is 5.1 percentage points below the measured one, within the range that was stated.
By their numbers in this assay, from the lowest: compounds 2, 4, 1 and 3 (each within the scatter of the next, the first and the last beyond it).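

In this assay, within the data shown here, the step of a number 0.8 percentage points lower from compound 1 to compound 4 (within the scatter) is the first reading at the ketone end of the series, and it leaves compound 1 and compound 4 indistinguishable on this read-out. For this pair, therefore, the maximal response does not depend on the isopropyl on a saturated chain carbon bound to a carbonyl carbon, and the isobutylcarbonyl group can be cut back to acetyl without a step beyond the scatter. No available evidence bears on why this is so.

On these data alone, this reading rests on the 4-carboxy-2-methylphenyl compounds alone, so it remains open whether acetyl behaves the same way with the 4-carboxy-3-methylphenyl ring of compound 3. Also open, as far as these compounds go, is how an amine, a phenyl ring or a longer chain at this carbon would read.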